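Removing the chloro group from compound 3

This account rests on a few compounds, and the source may have more. Where it says the series, first, only, none or still open, it means among the compounds named here.

The series shares one core, shown in compound 1 `O=C(Cn1cc(COc2ccc3c(c2)CCC3)nn1)Nc1ccc(Cl)cc1`, compound 2 `Cc1cc(C)c(-n2cc(COc3ccc4c(c3)CCC4)nn2)c(C)c1` and compound 3 `Clc1ccc(-n2cc(COc3ccc4c(c3)CCC4)nn2)cc1`. In an ADME assay on HEK293 cells (Homo sapiens) for inhibition, read by MTT assay, with a stated time of 48 h, tested at 25 uM (on this read-out higher numbers stand for more inhibition at the one concentration tested (going by the name of the read-out) and lower numbers for less inhibition), compound 1 gives "not determined" (no result reported). In this assay compound 2 gives 16.6%. In this assay, within the data shown here, compound 3 gives "not determined" (no result reported), so compound 3 stands without a single number, as does compound 1, and the only number in the set belongs to compound 2.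

Compound 4 `c1ccc(-n2cc(COc3ccc4c(c3)CCC4)nn2)cc1` differs from compound 3 by one change: hydrogen in place of chloro on an aromatic carbon. Among the measured compounds shown here, no measured pair in the set shares this change, so the size of the step from compound 3 to compound 4 in this assay cannot be read from data. The account expects no step beyond the usual scatter in this assay, in either direction, and leans on compound 2, which in this assay gives 16.6%, as the only anchor. Compound 4 is therefore expected to give about 15% in this assay, with a range from 0% to 35%.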

Compound 4, a percentage reported as inhibition, at one concentration (the size of the read-out at that concentration, not a potency): 23.4%
Compound 4: middle estimate off by 8.4 percentage points, on the low side; the range from low to high includes it.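

Among these compounds, compound 3 has no single number in this assay, so no step between compound 3 and compound 4 can be read. The compounds shown leave open how far, and in which direction, going from 4-chlorophenyl to phenyl shifts this read-out. Nothing given here offers an explanation for the result of compound 4.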